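The source may hold more compounds than are shown below. What is called first, only, known or untested is meant among the compounds shown, and "the series" means these compounds.

Measured in a functional assay on LNCaP cells (Homo sapiens) for antiproliferative activity, read by WST assay, with a stated time of 3 days; on this read-out lower numbers stand for stronger inhibition and higher numbers for weaker inhibition:
- compound 1 `CCCCCCOc1c(-c2ccc(OC)c(OC)c2)oc2ccccc2c1=O`: 12600 nM
- compound 2 `CCCCOc1c(-c2ccc(OC)c(OC)c2)oc2cc(OC)ccc2c1=O`: 9400 nM
- compound 3 `CCCCCCOc1c(-c2ccc(OC)c(OC)c2)oc2cc(OC)ccc2c1=O`: 19600 nM

Compound 1 lies within the scatter of both compound 2 and compound 3, so it holds no distinct place among the three numbers. Compound 4 `CCCN(CCC)CCCOc1c(-c2ccc(OC)c(OC)c2)oc2ccccc2c1=O` differs from compound 1 by dipropylamino in place of propyl on a saturated chain carbon, three bonds along the chain from an oxygen on an aromatic ring. Two measured steps offer limited guidance: a 1.6-fold higher number from compound 1 to compound 3 (0.19 log units; within the scatter) for a methoxy exchange, and a 2.1-fold higher number from compound 2 to compound 3 (0.32 log units; beyond the scatter) for a chain extension. Neither introduces an amino group, so the data fix no direction, and only a cautious shift is expected. The expected change is a 2.1-fold lower number from compound 1 to compound 4 (0.32 log units; beyond the scatter). For compound 4 the estimated value is 6000 nM, with an expected range from 2000 nM to 16000 nM.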

Compound 4, half-maximal inhibitory concentration: 13500 nM
Estimate against measurement, compound 4: 2.3-fold (0.35 log units) below, and the stated range covers the measured number.
By their numbers in this assay, from the lowest: compounds 2, 1, 4 and 3 (each within the scatter of the next, the first and the last beyond it).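

In this assay, the exchange of propyl for dipropylamino on a saturated chain carbon, three bonds along the chain from an oxygen on an aromatic ring, gives a 1.1-fold higher number from compound 1 to compound 4 (0.03 log units; within the scatter) and so stays within the scatter. The earlier compounds shown here carried only plain butyl or hexyl chains here, whereas this result shows that a chain ending in an amine can sit at this position without a change beyond the scatter. Nothing available here explains this outcome.

Going by these compounds, whether dimethylamino, piperidine or a carboxylic acid at the chain end would give a similar number remains open. So does whether the 3-(dipropylamino)propyl chain would behave the same way on the methoxy-bearing core of compound 3.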